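An added chloro on compound 2

The compounds below may be only part of what the source reports. "The series", "measured", "known", "first", "only" and "open" are said of these compounds alone.

Compound 1 `C=C(Br)C(=O)Nc1ccc(/C=C/C(=O)c2ccc(Cl)c(Cl)c2)cc1`: 1800 nM 
Compound 2 `Nc1ccc(/C=C/C(=O)c2ccc(Cl)cc2)cc1`: 7800 nM 

Both values come from a functional assay on MOLT-4 cells (Homo sapiens) for antiproliferative activity, with a stated time of 48 h; on this read-out higher numbers stand for weaker inhibition and lower numbers for stronger inhibition. Compound 2 has the higher of the two numbers, so it is the weaker inhibitor of this pair, and the gap to compound 1 lies beyond the usual scatter of repeated measurements. The two compounds differ in more than one place, so that gap cannot be tied to any single structural change.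

Compound 3 `Nc1ccc(/C=C/C(=O)c2ccc(Cl)c(Cl)c2)cc1` has not yet been measured. It is compound 2 with one change: chloro in place of hydrogen on an aromatic carbon, ortho to a chloro group and meta to a large group (chloro in place of hydrogen on an aromatic carbon). Compound 1, at 1800 nM in this assay, also carries this chloro, but it differs from compound 3 elsewhere as well, so it offers only a weak hint. A small move towards a lower number is expected, and it may not stand clear of the scatter. The expected step is a 1.7-fold lower number from compound 2 to compound 3 (0.24 log units; within the scatter) in this assay. For compound 3 the estimate is 4500 nM, with 1800 nM to 11000 nM as the expected range.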

Compound 3, half-maximal inhibitory concentration: 13000 nM
For compound 3 the middle estimate is 2.9-fold (0.46 log units) below the measured one; measured number outside the range, above it.
By their numbers in this assay, from the lowest: compound 1; then compounds 2 and 3 (each within the scatter of the next).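

In this assay, the step for chloro in place of hydrogen on the aromatic carbon ortho to a chloro group and meta to a large group is a 1.7-fold higher number from compound 2 to compound 3 (0.22 log units; within the scatter), so on this free-amine compound the second chloro has no effect that stands clear of repeat-measurement noise. Compound 3 also pairs with compound 1 through a single change on the nitrogen, hydrogen in place of (1-bromoethenyl)carbonyl, and that step is a 7.2-fold higher number from compound 1 to compound 3 (0.86 log units; beyond the scatter), which places a real difference at the nitrogen rather than on the chlorinated ring. Nothing available explains either result.

Still open is whether the second chloro would remain as silent with the (1-bromoethenyl)carbonyl group on the nitrogen, since no compound shown carries that group with only one chloro. Also open, from the compounds shown here alone, is whether the bromine or the carbon-carbon double bond matters at the nitrogen, which a plain acetyl group there could help to separate, and whether a methoxy group or a nitrile in place of the second chloro would give a clearer step.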